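The compounds below may be only part of what the source reports. "The series", "measured", "known", "first", "only" and "open" are said of these compounds alone.

Measured so far in an assay on isolated protein (urine) for inhibition of Myeloperoxidase (Homo sapiens), read by spectrophotometry; a lower number here means a stronger inhibitor, a higher number a weaker inhibitor:
compound 1 `CCCCn1nc2ccccc2c1OC` gives 910 nM;
compound 2 `COc1c2ccccc2nn1CCCCCO` gives 1540 nM.

Of the two numbers in this assay, compound 2 has the higher one, and its nearest neighbour is compound 1; the two differ by a 1.7-fold higher number from compound 1 to compound 2 (0.23 log units; within the scatter), so nothing separates them beyond the scatter.

Compound 3 `COCCn1nc2ccccc2c1OC` differs from compound 2 in one place: methoxy in place of 3-hydroxypropyl on a saturated chain carbon, two bonds along the chain from an aromatic nitrogen. Among the compounds with values here, no measured pair carries exactly this change. Within the data shown here, the only step at hand, a 1.7-fold higher number from compound 1 to compound 2 (0.23 log units; within the scatter), shows that a hydroxyl-bearing extension of the chain on the aromatic nitrogen leaves the number where it was; the reverse direction, cutting the chain back and replacing the hydroxyl with a methoxy, has no precedent here. On that footing the expected step is a 1.4-fold lower number from compound 2 to compound 3 (0.15 log units; within the scatter), no more than the scatter, with the number for compound 3 estimated at 1100 nM, expected to lie between 400 nM and 3500 nM.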

Compound 3, half-maximal inhibitory concentration: 1080 nM
For compound 3 the middle estimate is 1.0-fold (0.01 log units) above the measured one; the range from low to high includes it.
By their numbers in this assay, from the lowest: compounds 1, 3 and 2 (each within the scatter of the next).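

In this assay, methoxy in place of 3-hydroxypropyl on a saturated chain carbon, two bonds along the chain from an aromatic nitrogen, gives a 1.4-fold lower number from compound 2 to compound 3 (0.15 log units; within the scatter), so removing the hydroxyl and shortening the chain in one change leaves the reading within the scatter. At the same place, methoxy in place of ethyl gives a 1.2-fold higher number from compound 1 to compound 3 (0.07 log units; within the scatter), which is also within the scatter, so compounds 1, 2 and 3 show this chain carrying a plain alkyl end, a hydroxyl or a methoxy without a step beyond the scatter. Nothing measured on these compounds offers a reason for this flat result.

On these data alone, whether the flat result extends to an amine or a carboxylic acid on this chain remains open. The shared core is constant across compounds 1, 2 and 3, so the effect of replacing its methoxy with an amine is also unknown.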